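The source may hold more compounds than are shown below. What is called first, only, known or untested is meant among the compounds shown, and "the series" means these compounds.

Working notes on the series. In a functional assay on SK-BR-3 cells (Homo sapiens) for antiproliferative activity, read by MTT assay, with a stated time of 72 h (on this read-out lower numbers stand for stronger inhibition and higher numbers for weaker inhibition), compound 1 (`C#CCOC(=O)C[C@@H]1C(C(=O)OC)=CO[C@@H](O[C@@H]2O[C@H](COC(C)=O)[C@@H](OC(C)=O)[C@H](OC(C)=O)[C@H]2OC(C)=O)/C1=C/C`) stands at > 15000 nM, which is a limit and not a number. Compound 2 (`C/C=C1/[C@H](O[C@@H]2O[C@H](CO)[C@@H](O)[C@H](O)[C@H]2O)OC=C(C(=O)OC)[C@H]1CC(=O)OCCCc1ccc(OC)c(OC)c1`) gives > 20000 nM, also a limit. The next compound to be read is compound 3 (`C/C=C1/[C@H](O[C@@H]2O[C@H](COC(C)=O)[C@@H](OC(C)=O)[C@H](OC(C)=O)[C@H]2OC(C)=O)OC=C(C(=O)OC)[C@H]1CC(=O)SCCC`), which keeps the core of compound 1 and changes one group: propylsulfanyl in place of propargyloxy on a carbonyl carbon. The change is propylsulfanyl in place of propargyloxy on a carbonyl carbon. For the measured compounds named here, no measured pair shows what a change of this kind does. The expectation therefore rests on compound 1 alone, with its limit of > 15000 nM, and no shift beyond the usual scatter is expected in this assay, in either direction. The expected size of the change is a number no higher from compound 1 to compound 3 (the limit leaves the size open). For compound 3 the estimated value is 15000 nM, with an expected range from 5000 nM to 30000 nM.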

Compound 3, half-maximal inhibitory concentration: > 15000 nM
Compound 3 gave a limit, no number (the forecaster's own chance of this, stated with the estimate: 65%); the middle value sits exactly at the limit.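

In this assay compound 3 gives > 15000 nM, which is a limit and not a number. Compound 1 also has only a limit, so no step can be read between compound 1 and compound 3. On these data alone, the effect of propylsulfanyl in place of propargyloxy on a carbonyl carbon stays open.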